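This account rests on a few compounds, and the source may have more. Where it says the series, first, only, none or still open, it means among the compounds named here.

Measured so far in a functional assay on P388 cells (Mus musculus) for cytotoxicity; on this read-out higher numbers stand for an effect only at larger amounts of compound and lower numbers for an effect already at smaller amounts:
compound 1, `Oc1ccc2c(O)cc(-c3ccccc3)nc2c1`, gives 0.81 ug/mL
compound 2, `Oc1cc(-c2ccccc2)nc2cc(F)ccc12`, gives 0.29 ug/mL
compound 3, `Oc1cc(-c2ccccc2)nc2c(O)cccc12`, gives only a limit, > 10 ug/mL

Compound 1 and compound 3 have the same atoms joined differently; the difference between the two cores is not broken down here. From compound 1 to compound 2 the change is fluoro in place of hydroxy on an aromatic carbon, and in this assay it brings a 2.8-fold lower number from compound 1 to compound 2 (0.45 log units; beyond the scatter).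

Compound 4, `Oc1cc(-c2ccccc2)nc2c(F)cccc12`, is not yet measured in this assay. It differs from compound 3 by fluoro in place of hydroxy on an aromatic carbon. This is the same kind of change as from compound 1 to compound 2, but not the same: there the place is meta to a fused ring and para to a fused ring, here ortho to a fused ring and meta to a fused ring. The starting point also differs, since compound 3 sits at the limit of > 10 ug/mL in this assay, at which 1 of the 3 values shown sits, so the measured step gives only a loose guide. Taking the earlier step as a rough direction, the step from compound 3 to compound 4 is expected to be about an at least 2.5-fold lower number from compound 3 to compound 4 (0.39 log units; beyond the scatter), with wide uncertainty. Compound 4 is therefore estimated at 4 ug/mL, between 0.8 ug/mL and 20 ug/mL.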

Compound 4, half-maximal effective concentration: 0.67 ug/mL
For compound 4 the middle estimate is 6.0-fold (0.78 log units) above the measured one, outside the stated range (below it).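

In this assay, fluoro in place of hydroxy gives an at least 14-fold lower number from compound 3 to compound 4 (1.17 log units; beyond the scatter), so the direction of the change carries over from one core to the other, but its size does not: the same change on two cores in this assay, a 2.8-fold lower number (0.45 log units; beyond the scatter) from compound 1 to compound 2 and an at least 14-fold lower number (1.17 log units; beyond the scatter) from compound 3 to compound 4, at least 5.3-fold (0.72 log units) apart, beyond the scatter of two such steps

Compound 3 gives > 10 ug/mL, which is a limit of the assay and not a number, so this step is known only as a bound. The two pairs differ both in the core and in the place of the change, which for the second pair is ortho to a fused ring and meta to a fused ring, so they do not show which of the two goes with the gap.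

Open, going by these compounds, is whether a chloro or a methoxy at the same place would follow fluoro on either core. Also open, on these data alone, is what happens when the other hydroxy, shared by all four compounds, gives way to an amine.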